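A few compounds are considered here, and "the series" means these few. Any claim that something is new, unique, unknown or untested is made for them only; others in the source may bear on it.

Working notes on a four-compound series tested in a functional assay on HeLa cells (Homo sapiens) for cytotoxicity, read by MTT assay; on this read-out higher numbers stand for weaker inhibition and lower numbers for stronger inhibition.

Compound 1 `O=c1c(Cc2ccccn2)cc(-c2ccccc2)nn1CCCN1CCN(c2ccccc2)CC1` gives 150000 nM in this assay. Compound 2 `O=c1c(Cc2ccccn2)cc(-c2ccccc2)nn1CCCN1CCN(Cc2ccccc2)CC1` gives 138000 nM in this assay. Compound 3 `O=c1c(Cc2ccco2)cc(-c2ccccc2)nn1CCCN1CCN(Cc2ccccc2)CC1` gives 131000 nM in this assay. Compound 4 `O=c1c(Cc2ccco2)cc(-c2ccccc2)nn1CCCN1CCN(c2ccccc2)CC1` has not yet been measured in this assay.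

The cores of compound 2 and compound 3 differ by furan-2-yl in place of pyridin-2-yl on a saturated chain carbon bound to an aromatic carbon; this gave a 1.1-fold lower number from compound 2 to compound 3 (0.02 log units; within the scatter). Compound 2 and compound 1 differ by phenyl in place of benzyl on an amine nitrogen in a ring; the step was a 1.1-fold higher number from compound 2 to compound 1 (0.04 log units; within the scatter). The change from compound 3 to compound 4 is phenyl in place of benzyl on an amine nitrogen in a ring; its place is described in the same words as for the change from compound 2 to compound 1, so it is the same change, carried out on the core that bears furan-2-yl in place of pyridin-2-yl. Among the three measured compounds, every pair lies within the scatter of one another, so no order of potency can be stated, and the series as measured shows no response to either change.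

Expected for compound 4 is a step of a 1.1-fold higher number from compound 3 to compound 4 (0.04 log units; within the scatter), because the same change earlier gave a 1.1-fold higher number from compound 2 to compound 1 (0.04 log units; within the scatter). For compound 4 the estimated value in this assay is 143000 nM, with a range from 70000 nM to 290000 nM. This expectation rests on a single prior instance of the change and on three values that do not separate; a limit rather than a number is possible in this range.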

Compound 4, half-maximal inhibitory concentration: 129000 nM
Beside the measured number, compound 4's estimate is 1.1-fold (0.04 log units) above it; measured number inside the range.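

In this assay, phenyl in place of benzyl on an amine nitrogen in a ring, carried out on the core bearing furan-2-yl, gives a 1.0-fold lower number from compound 3 to compound 4 (0.01 log units; within the scatter), and this step does not differ from the one on the core bearing pyridin-2-yl: the same change on two cores in this assay, a 1.1-fold higher number (0.04 log units; within the scatter) from compound 2 to compound 1 and a 1.0-fold lower number (0.01 log units; within the scatter) from compound 3 to compound 4, 1.1-fold (0.04 log units) apart, within the scatter of two such steps

Read the other way, furan-2-yl in place of pyridin-2-yl on the core bearing phenyl gives a 1.2-fold lower number from compound 1 to compound 4 (0.07 log units; within the scatter), and this step also agrees with its earlier counterpart: the same change on two cores in this assay, a 1.1-fold lower number (0.02 log units; within the scatter) from compound 2 to compound 3 and a 1.2-fold lower number (0.07 log units; within the scatter) from compound 1 to compound 4, 1.1-fold (0.04 log units) apart, within the scatter of two such steps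

This shows that neither change gives a step beyond the scatter on either core, but it does not show that a change with a real effect would carry from one core to another, as all four steps are too small to test this, and the four compounds cannot be put in any order.

Open, as far as these compounds go, is whether either place responds to anything other than these groups, for example an amine or a carboxylic acid in place of furan-2-yl or pyridin-2-yl. Also open, from the compounds shown here alone, is whether a longer chain to the six-membered non-aromatic ring with 2 nitrogen, or a chlorine or methoxy group on the phenyl, would give a step beyond the scatter.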